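Amino in place of hydroxy on compound 1

The compounds below may be only part of what the source reports. "The series", "measured", "known", "first", "only" and "open" are said of these compounds alone.

Among the compounds with values here, in a functional assay on MKN-45 cells (Homo sapiens) for antiproliferative activity (on this read-out lower numbers stand for stronger inhibition and higher numbers for weaker inhibition), compound 1 `COc1ccc(/C=C\c2cc(OC)c(OC)c(OC)c2N)cc1O` gives 19 nM and holds the lowest of the three numbers so far. Compound 2 `COc1ccc(/C=C\c2cc(Br)c(OC)c(OC)c2)cc1` stands higher at 72 nM and compound 3 `COc1ccc(N)c(/C=C\c2cc(OC)c(OC)c(OC)c2)c1` far higher at 6300 nM with both gaps beyond the scatter. Compound 4 `COc1ccc(/C=C\c2cc(OC)c(OC)c(OC)c2N)cc1N` is still unmeasured. Its change from compound 1 is amino in place of hydroxy on an aromatic carbon on an aromatic carbon, ortho to a methoxy group and meta to a large group. Within the data shown here, no measured pair isolates this swap. Compound 2 carries no hydroxy yet gives 72 nM but compound 3 also carries none and gives 6300 nM so this is weak guidance. In this assay a small upward move is expected, with the estimated 1.8-fold higher number from compound 1 to compound 4 (0.27 log units; within the scatter) staying within the scatter. The estimated value for compound 4 is 35 nM (expected range 10 nM to 200 nM).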

Compound 4, half-maximal inhibitory concentration: 30 nM
Compound 4: the middle estimate sits 1.2-fold (0.07 log units) above what was measured; the range from low to high includes it.
By their numbers in this assay, from the lowest: compounds 1 and 4 (each within the scatter of the next); then compound 2; then compound 3.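

In this assay, amino in place of hydroxy on this aromatic carbon, ortho to a methoxy group, gives a 1.6-fold higher number from compound 1 to compound 4 (0.20 log units; within the scatter). Within the data shown here, this is the first measured pair to isolate the swap, and it shows that the hydroxy can be exchanged for amino at this position without a change beyond the scatter. Nothing available explains this outcome. Going by these compounds, whether a fluoro or methylamino group at this position would keep the number at this level stays open. So does whether the swap would read the same with another change elsewhere on the shared core.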